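Replacing the indolyl group of compound 1 with a fluoro-methoxyphenyl

The source may report more compounds than this note shows. Statements on the series, on what has been measured and on what is new or still open speak of the compounds shown alone.

Compound 1 `COc1cc(-c2ccnc3cc(-c4ccc5c(ccn5C)c4)nn23)cc(OC)c1OC` gives 19 nM in a functional assay on HeLa cells (Homo sapiens) for inhibition, read by CCK-8 assay, with a stated time of 48 h (on this read-out lower numbers stand for stronger inhibition and higher numbers for weaker inhibition), the lowest of the three numbers recorded. Compound 2 `COc1cc(-c2ccnc3cc(-c4ccc(C(C)=O)cc4)nn23)cc(OC)c1OC` gives 1810 nM in this assay, and compound 3 `COc1cc(-c2ccnc3cc(-c4cccc5c4ccn5CO)nn23)cc(OC)c1OC` gives 456 nM. Within the data shown here, the one step that changes a single place, a 95-fold higher number from compound 1 to compound 2 (1.98 log units; beyond the scatter), shows that exchanging the bicyclic group for a single six-membered ring carrying a carbonyl costs a great deal of inhibition. Compound 4 `COc1ccc(-c2cc3nccc(-c4cc(OC)c(OC)c(OC)c4)n3n2)cc1F` is not yet measured; it differs from compound 1 as follows: 3-fluoro-4-methoxyphenyl in place of 1-methyl-1H-indol-5-yl on an aromatic carbon. Among the measured compounds shown here, this change resembles the one from compound 1 to compound 2, since a single-ring aryl again takes the place of the indolyl, though the entering group here carries a fluorine and a methoxy rather than an acetyl. Compound 3 shows only that a differently attached indolyl with a hydroxymethyl also gives a higher number than compound 1. A clear loss of potency is therefore expected for compound 4, smaller perhaps than for compound 2, with the step estimated as an 18-fold higher number from compound 1 to compound 4 (1.27 log units; beyond the scatter). The value for compound 4 is estimated at 350 nM, within 60 nM to 2000 nM.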

Compound 4, half-maximal inhibitory concentration: 236 nM
The estimate for compound 4 lay 1.5-fold (0.17 log units) above the measured number, and the stated range covers the measured number.
By their numbers in this assay, from the lowest: compound 1; then compounds 4 and 3 (each within the scatter of the next); then compound 2.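

With 3-fluoro-4-methoxyphenyl on this aromatic carbon, this assay gives a 12-fold higher number from compound 1 to compound 4 (1.09 log units; beyond the scatter), so the large loss on leaving 1-methyl-1H-indol-5-yl is not confined to 4-acetylphenyl but also appears with a second single-ring aryl group. The two single-ring groups are not equivalent either, with a 7.7-fold lower number from compound 2 to compound 4 (0.88 log units; beyond the scatter), which shows that the substituents on the entering phenyl ring also affect the number at this position. Nothing measured here accounts for either step.

The compounds shown do not separate the contribution of the fluorine from that of the methoxy on the phenyl ring. They also leave open how the number would respond to a phenyl ring carrying an amine or a carboxylic acid at this position.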